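Carbamate Replaced by a Fluorinated Amide on the Piperidine Nitrogen

The compounds below may be only part of what the source reports. "The series", "measured", "known", "first", "only" and "open" are said of these compounds alone.

Compound 1 `Cc1nc(S(C)(=O)=O)ccc1Oc1ncnc(OC2CCN(C(=O)O[C@H](C)CF)CC2)c1F`: 1520 nM
Compound 2 `Cc1nc(S(C)(=O)=O)ccc1Oc1ncnc(OC2CCN(C(=O)O[C@H](C)C(F)(F)F)CC2)c1F`: 110 nM
Compound 3 `CCC1(OC(=O)N2CCC(Oc3ncnc(Oc4ccc(S(C)(=O)=O)nc4C)c3F)CC2)CC1`: 333 nM

The three measured compounds share one core and differ only in the group attached to a carbonyl carbon whose other neighbour is an amide-type nitrogen in a ring. In a functional assay on isolated protein for inhibition of Glucose-dependent insulinotropic receptor (Rattus norvegicus), read by HTRF and cAMP accumulation (a lower number here means that less compound is needed, a higher number that more compound is needed for the effect), compound 1 gives 1520 nM, compound 2 gives 110 nM and compound 3 gives 333 nM. Compound 3 thus stands second highest of the three, with compound 2 nearest and compound 1 furthest. Of the measured steps, a 14-fold lower number from compound 1 to compound 2 (1.14 log units; beyond the scatter) is the largest, a 4.6-fold lower number from compound 1 to compound 3 (0.66 log units; beyond the scatter) is smaller, and a 3.0-fold higher number from compound 2 to compound 3 (0.48 log units; beyond the scatter) runs the other way.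

Compound 4 `Cc1nc(S(C)(=O)=O)ccc1Oc1ncnc(OC2CCN(C(=O)C(C)(F)F)CC2)c1F` has not yet been measured. It differs from compound 3 by a group of 4 heavy atoms (2 carbon, 2 fluorine; no ring) in place of a group of 6 heavy atoms (5 carbon, 1 oxygen; one three-membered non-aromatic ring of carbon only), on a carbonyl carbon. For the measured compounds named here, no measured step removes the oxygen on the carbonyl carbon, so the earlier steps bear on this change only loosely. The entering fluorines are worth noting because a 14-fold lower number from compound 1 to compound 2 (1.14 log units; beyond the scatter) was the largest step seen, yet the entering group is smaller and lacks the oxygen. A modest rise in the number is expected, a 2.1-fold higher number from compound 3 to compound 4 (0.32 log units; beyond the scatter). Compound 4 is estimated at 700 nM, within 150 nM to 3000 nM.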

Compound 4, half-maximal effective concentration: 239 nM
The estimate for compound 4 lay 2.9-fold (0.47 log units) above the measured number; low and high end bracket the measured number.
By their numbers in this assay, from the lowest: compound 2; then compounds 4 and 3 (each within the scatter of the next); then compound 1.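

In this assay, an oxygen on the carbonyl carbon turns out not to be required: swapping the larger ring-bearing group for 1,1-difluoroethyl gives a 1.4-fold lower number from compound 3 to compound 4 (0.14 log units; within the scatter), so these two compounds cannot be told apart here. The same oxygen-free group still falls short of the best carbamate, with a 2.2-fold higher number from compound 2 to compound 4 (0.34 log units; beyond the scatter), yet it clearly beats the fluoromethyl carbamate, with a 6.4-fold lower number from compound 1 to compound 4 (0.80 log units; beyond the scatter). No supporting evidence is available to explain these differences.

On these data alone, what a plain ethyl group on the carbonyl carbon would give remains open, so the part played by the two fluorines in 1,1-difluoroethyl cannot be judged. Also open, as far as these compounds go, is how a longer chain, such as 1,1-difluoropropyl, or a cyclopropyl ring placed directly on that carbon would compare.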